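Cytotoxicity notes on compounds 1 to 3

The source may report more compounds than this note shows. Statements on the series, on what has been measured and on what is new or still open speak of the compounds shown alone.

Measured so far:
compound 1 `CCc1ccc(NC(=O)Nc2cc(C)nc3ccccc23)cc1`: > 25000 nM
compound 2 `Cc1cc(NC(=O)Nc2cc(F)cc(F)c2)c2ccccc2n1`: > 25000 nM

In an ADME assay on BJ cells (Homo sapiens) for cytotoxicity, with a stated time of 72 h (on this read-out higher numbers stand for an effect only at larger amounts of compound and lower numbers for an effect already at smaller amounts), compound 1 gives > 25000 nM, which is a limit of the assay and not a number. Compound 2 likewise gives only a limit there, > 25000 nM. So (the limit of > 25000 nM in this assay, at which 2 of the 2 values shown sit); compound 1 stands at the same limit as the only other measured compound, and no order between the two can be drawn. Compound 3 `COc1ccc(NC(=O)Nc2cc(C)nc3ccccc23)cc1` is not yet measured; it differs from compound 1 by methoxy in place of ethyl on an aromatic carbon. Going by the values given here, no measured step of this kind exists, and no shift beyond the usual scatter is expected in this assay in either direction. The step that the limit leaves unreadable from compound 1 to compound 3 is expected to be essentially none. Compound 3 is estimated at 40000 nM, expected between 20000 nM and 100000 nM, and most likely reported again only as a limit.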

Compound 3, half-maximal effective concentration: > 25000 nM
Compound 3 ended at the assay's limit (the forecaster's own chance of this, stated with the estimate: 85%); the middle value does not contradict the limit.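

No step can be read from compound 1 to compound 3, since both sit at a limit in this assay: the limit of > 25000 nM in this assay, at which 3 of the 3 values shown sit.

Still open, going by these compounds, is where compound 1, compound 2 and compound 3 truly lie beyond that limit, and whether they differ at all.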